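The source may report more compounds than this note shows. Statements on the series, on what has been measured and on what is new or still open speak of the compounds shown alone.

For the measured compounds named here, in a functional assay on A549 cells (Homo sapiens) for antiproliferative activity, read by MTT assay, with a stated time of 72 h (a lower number here means a stronger inhibitor, a higher number a weaker inhibitor), compound 3 (`Cc1nc(C)c(/C=C/C(=O)/C=C/c2ccccc2)nc1C`) gives 12300 nM as its reading, the highest number of the three measured so far and so the weakest inhibitor among them. Compound 1 (`COc1ccccc1/C=C/C(=O)/C=C/c1nc(C)c(C)nc1C`) stands at 3200 nM and compound 2 (`COc1cccc(/C=C/C(=O)/C=C/c2nc(C)c(C)nc2C)c1`) at 3300 nM with no real gap between them. The change from compound 3 to compound 4 (`Cc1ccc(/C=C/C(=O)/C=C/c2nc(C)c(C)nc2C)cc1`) is methyl in place of hydrogen on an aromatic carbon and amounts to methyl in place of hydrogen on an aromatic carbon, turning phenyl into 4-methylphenyl. Going by the values given here, no methyl step has been measured, so the nearest guides are the two methoxy steps. Both a 3.8-fold higher number from compound 1 to compound 3 (0.58 log units; beyond the scatter) and a 3.7-fold higher number from compound 2 to compound 3 (0.57 log units; beyond the scatter) show the number rising when hydrogen replaces methoxy, and both are modest but beyond the scatter. Adding a group to compound 3 may therefore lower the number, although methyl is not methoxy and the gain may well be smaller. The expected change is a 1.9-fold lower number from compound 3 to compound 4 (0.28 log units; within the scatter) in this assay and would be modest at best. For compound 4 the estimated value is 6500 nM with 2800 nM to 14000 nM as the expected range.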

Compound 4, half-maximal inhibitory concentration: 4300 nM
The estimate for compound 4 lay 1.5-fold (0.18 log units) above the measured number; measured number inside the range.
By their numbers in this assay, from the lowest: compounds 1, 2 and 4 (each within the scatter of the next); then compound 3.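

In this assay, putting methyl on the phenyl ring of compound 3 gives a 2.9-fold lower number from compound 3 to compound 4 (0.46 log units; beyond the scatter), so a group with a single carbon and 0 hydrogen-bond acceptors is enough to produce a step beyond the scatter. Until now, only methoxy, at other places on the ring, had been seen to lower the number relative to compound 3; this result extends the effect to a different group and to the place on the ring para to a large group. What lies behind the drop remains unexplained, as no supporting measurement bears on it.

The compounds shown leave open whether a longer chain such as ethyl, or an amine or a carboxylic acid, would lower the number further at this place. They also leave open how methoxy at this same place would compare with methyl.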